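A Halogen Swap on the Amide of Compound 1

The source may hold more compounds than are shown below. What is called first, only, known or untested is meant among the compounds shown, and "the series" means these compounds.

For the measured compounds named here, compound 1 `CCOC(=O)C1=Cc2ccccc2OC1(OCc1cn(CC(=O)Nc2cccc(Cl)c2)nn1)C(F)(F)F` is the only member of this small set that returns a number. In a functional assay on A549 cells (Homo sapiens) for inhibition, read by MTT assay, with a stated time of 24 h (a higher number here means a weaker inhibitor, a lower number a stronger inhibitor), compound 1 gives 12800 nM. The two other values shown are limits of the assay rather than numbers. Compound 2 `CCOC(=O)C1=Cc2ccccc2OC1(OCc1cc(-c2ccc([N+](=O)[O-])cc2)no1)C(F)(F)F` returns in this assay only a limit, > 150000 nM. Compound 3 `O=C(O)C1=Cc2ccccc2OC1(OCc1cc(-c2ccc(F)cc2F)no1)C(F)(F)F` likewise returns in this assay only a limit, > 150000 nM. Compound 1 therefore stands alone as the measurable inhibitor, the other two sitting at the limit of > 150000 nM in this assay, at which 2 of the 3 values shown sit.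

Compound 4 `CCOC(=O)C1=Cc2ccccc2OC1(OCc1cn(CC(=O)Nc2ccccc2F)nn1)C(F)(F)F` differs from compound 1 in one place: 2-fluorophenyl in place of 3-chlorophenyl on an amide-type nitrogen. Going by the values given here, no pair of measured compounds in this set shares that change, so there is no measured step to lean on; of compounds 2 and 3 only their limits are known. The shared core and the rest of the side chain of compound 1 are kept in compound 4, with 2-fluorophenyl in place of 3-chlorophenyl on the amide-type nitrogen. Such a change is expected to shift the reading only a little, most likely within the usual scatter or slightly toward weaker inhibition, as a 1.6-fold higher number from compound 1 to compound 4 (0.19 log units; within the scatter). Compound 4 is accordingly estimated at 20000 nM, with a range from 6000 nM to 70000 nM.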

Compound 4, half-maximal inhibitory concentration: 50100 nM
Estimate against measurement, compound 4: 2.5-fold (0.40 log units) below; the measured number falls inside the stated range.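

In this assay, for the compounds shown here, the group on the amide-type nitrogen turns out to be a place where the reading responds: 2-fluorophenyl in place of 3-chlorophenyl gives a 3.9-fold higher number from compound 1 to compound 4 (0.59 log units; beyond the scatter), the first step in this set that can be read at all. The step is modest but lies beyond the usual scatter, even though the two groups match in heavy-atom count, in their single six-membered aromatic ring and in having no hydrogen-bond donors or acceptors, so the position is not indifferent to a change confined to the halogen and where it sits on the ring. Compound 4 still returns a number, as compound 1 does, while two of the values shown remain a limit of the assay and not a number: the limit of > 150000 nM in this assay, at which 2 of the 4 values shown sit.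

This single step changes the halogen and its place on the ring together, so the compounds shown cannot tell which of the two carries the shift. On these data alone, how the reading would respond to a plain phenyl, or to a phenyl bearing a methoxy group or a carboxylic acid, on the same amide-type nitrogen also remains open.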